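The source may hold more compounds than are shown below. What is called first, only, known or untested is meant among the compounds shown, and "the series" means these compounds.

Measured so far: compound 1 `COc1cc(/C=N/NC(=O)OCc2ccccc2)ccc1O` gives 73%; compound 2 `COc1cc(/C=N/Nc2nc3ccccc3s2)ccc1O` gives 44%; compound 3 `COc1cc(/C=N/Nc2nc3ccccc3s2)cc(O)c1O` gives 38%, all in a functional assay on cells (Mus musculus) for cytotoxicity, read by MTT assay, with a stated time of 24 h, tested at 1 uM; on this read-out lower numbers stand for a weaker effect and higher numbers for a stronger effect at the one concentration tested.

Compound 1 and compound 2 share a left-hand part but carry different right-hand parts; the difference between the two cores is not broken down here. Between compound 2 and compound 3 a hydroxy group enters the ring (hydroxy in place of hydrogen on an aromatic carbon), and in this assay the read-out moves by a number 6 percentage points lower from compound 2 to compound 3 (within the scatter). Compound 4 `COc1cc(/C=N/NC(=O)OCc2ccccc2)c(O)cc1O` is compound 1 with the same kind of change (hydroxy in place of hydrogen on an aromatic carbon), though the surroundings differ: in compound 4 the new hydroxy sits ortho to a large group, meta to a hydroxy group and para to a methoxy group, whereas in compound 3 it sits ortho to a hydroxy group, meta to a large group and meta to a methoxy group. Because the change from compound 2 to compound 3 gave a number 6 percentage points lower from compound 2 to compound 3 (within the scatter), a similarly small step is expected from compound 1 to compound 4, namely a number 6 percentage points lower from compound 1 to compound 4 (within the scatter). For compound 4 in this assay a value of about 67% is estimated, most likely between 52% and 80%.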

Compound 4, a percentage reported as activity, at one concentration (the size of the read-out at that concentration, not a potency): 43%
Beside the measured number, compound 4's estimate is 24 percentage points above it; the whole stated range lies above it.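

In this assay, putting a hydroxy group in place of hydrogen on an aromatic carbon gives a number 30 percentage points lower from compound 1 to compound 4 (beyond the scatter), so the size of the step on one core does not carry over to the other: the same change on two cores in this assay, a number 6 percentage points lower (within the scatter) from compound 2 to compound 3 and a number 30 percentage points lower (beyond the scatter) from compound 1 to compound 4, 24 percentage points apart, beyond the scatter of two such steps

This does not show why the two steps differ, since the cores differ and the new hydroxy also sits in a different place on the ring, and these two pairs cannot separate those two differences. Nor do two pairs say how the change would behave on any other core in this series.

The compounds shown leave open what a hydroxy placed as in compound 3 would do on the core of compound 1. They also leave open whether an amine or a carboxylic acid in the place of the new hydroxy of compound 4 would behave alike.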